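The source may hold more compounds than are shown below. What is called first, only, known or untested is meant among the compounds shown, and "the series" means these compounds.

Compound 1, `CC(C)OC(=O)c1ccc(-c2nn(Cc3ccccc3)c3ccccc23)cc1`, gives in a functional assay on cells (Platelet, Homo sapiens) for inhibition (on this read-out lower numbers stand for stronger inhibition and higher numbers for weaker inhibition), only a limit, > 10000 nM.
Compound 2, `CNC(=O)c1ccc(-c2nn(Cc3ccccc3)c3ccccc23)cc1`, gives in this assay only a limit, > 10000 nM.
Compound 3, `CC(C)NC(=O)c1ccc(-c2nn(Cc3ccccc3)c3ccccc23)cc1`, gives in this assay only a limit, > 10000 nM.

All three measured compounds share one core and differ only in the group on the carbonyl carbon at the end of the phenyl ring. None of them yields a number: each sits at the limit of the assay, (the limit of > 10000 nM in this assay, at which 3 of the 3 values shown sit). The step that the two limits leave unreadable from compound 1 to compound 2, the step that the two limits leave unreadable from compound 1 to compound 3 and the step that the two limits leave unreadable from compound 2 to compound 3 therefore cannot be read in either direction. Compound 3 thus stands at the limit itself, and no order among compounds 1, 2 and 3 can be drawn.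

Compound 4, `CCOC(=O)/C=C/c1ccc(-c2nn(Cc3ccccc3)c3ccccc23)cc1`, arises from compound 3 by the change (2-(ethoxycarbonyl)ethenyl in place of isopropylcarbamoyl on an aromatic carbon). The ester is now carried on an ethenyl linker rather than sitting directly on the ring as an amide. Among the measured compounds shown here, no measured step touches this kind of change, and the three measured steps that do exist are all unreadable, so they give no direction and no size to expect. The most that can be said is that compound 3 shows no measurable inhibition, and without evidence of a gain the same outcome is expected for compound 4, that is, a step of a number no higher from compound 3 to compound 4 (the limit leaves the size open) that is essentially nil. Compound 4 is therefore estimated at 10000 nM, with a range from 3000 nM to 30000 nM, most likely again reported only as a limit.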

Compound 4, half-maximal inhibitory concentration: > 10000 nM
Compound 4 ended at the assay's limit (the forecaster's own chance of this, stated with the estimate: 80%); the middle value lies on the limit itself.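

Compound 4 ends at the same limit as compounds 1, 2 and 3, so none of the steps from those three to compound 4 can be read, and the four cannot be put in any order: the limit of > 10000 nM in this assay, at which 4 of the 4 values shown sit. Which change to the shared core, if any, would give a measurable number in this assay remains open.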